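Swapping a Selenocyanate Ester for a Thiocyanate Amide

A few compounds are considered here, and "the series" means these few. Any claim that something is new, unique, unknown or untested is made for them only; others in the source may bear on it.

Measured compounds:
compound 1, `CC(=O)Oc1ccccc1C(=O)OCC[Se]C#N`: 17600 nM
compound 2, `C[Se]CC(NC(=O)c1ccccc1OC(C)=O)C(=O)O`: > 50000 nM

In a functional assay on UACC-903 cells (Homo sapiens) for antiproliferative activity, read by MTT assay, with a stated time of 72 h (a higher number here means a weaker inhibitor, a lower number a stronger inhibitor), compound 1, with the structure `CC(=O)Oc1ccccc1C(=O)OCC[Se]C#N`, gives 17600 nM. For compound 2, with the structure `C[Se]CC(NC(=O)c1ccccc1OC(C)=O)C(=O)O`, the result in this assay is a limit of the assay and not a number, > 50000 nM (the limit of > 50000 nM in this assay, at which 1 of the 2 values shown sits). Compound 1 therefore holds the only actual number shown here; the one other value is a limit.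

Compound 3, with the structure `CC(=O)Oc1ccccc1C(=O)NCCSC#N`, has not been measured. It differs from compound 1 in one place: a group of 6 heavy atoms (3 carbon, 2 nitrogen, 1 sulfur; no ring) in place of a group of 6 heavy atoms (3 carbon, 1 nitrogen, 1 oxygen, 1 selenium; no ring), on a carbonyl carbon. No step between two measured compounds is shown, so no measured change of this kind can be pointed to, and the expectation rests on compound 1 alone.

For compound 3 the expected step is a 2.3-fold higher number from compound 1 to compound 3 (0.36 log units; beyond the scatter), toward weaker inhibition, beyond the usual scatter. Compound 3 is estimated at 40000 nM, within 15000 nM to 100000 nM, and may be reported only as a limit.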

Compound 3, half-maximal inhibitory concentration: > 50000 nM
Compound 3 gave a limit, no number; the forecaster's own chance of this, stated with the estimate: 40%; at least 1.2-fold (0.09 log units) between middle value and limit.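

Going by these compounds alone, this is the first readable step at this place, on a carbonyl carbon whose other neighbours are aromatic carbon: in this assay, putting (2-(cyanosulfanyl)ethyl)amino in place of the selenium-bearing ester group gives an at least 2.8-fold higher number from compound 1 to compound 3 (0.45 log units; beyond the scatter). The result for compound 3 is a limit of the assay and not a number, so the step shows that this single change moves the result beyond the scatter, but not how far. Compound 1 remains the only compound with an actual number because the other results stop at the same limit: the limit of > 50000 nM in this assay, at which 2 of the 3 values shown sit.

The change swaps the ester oxygen for an amide nitrogen and selenium for sulfur together, and this one step cannot separate the two. An amide carrying the selenocyanate, an ester carrying the thiocyanate, or a longer chain carrying either group would each be needed to tell which part matters.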